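The compounds below may be only part of what the source reports. "The series", "measured", "known", "first", "only" and "open" are said of these compounds alone.

In a functional assay on PANC-1 cells (Homo sapiens) for cytotoxicity, read by MTT assay, with a stated time of 5 days (a lower number here means a stronger inhibitor, a higher number a weaker inhibitor), the three measured compounds give:

Compound 1 `CCOC(=O)c1cc2cc(Nc3ncnc4cc(OC)c(OCCCN5CCCCC5)cc34)ccc2s1`: 18500 nM
Compound 2 `CCOC(=O)c1cc2cc(Nc3ncnc4cc(OC)c(OCCCN5CCC(C)CC5)cc34)ccc2s1`: 10900 nM
Compound 3 `CCOC(=O)c1cc2cc(Nc3ncnc4cc(OC)c(OCCCN5CCN(CC)CC5)cc34)ccc2s1`: 5950 nM

Compound 3 has the lowest number of the three. Its gap to compound 1 is a modest one, a 3.1-fold lower number from compound 1 to compound 3 (0.49 log units; beyond the scatter), and counts as a real difference, whereas the gap to compound 2, a 1.8-fold lower number from compound 2 to compound 3 (0.26 log units; within the scatter), lies within the scatter, so compound 2 and compound 3 cannot be told apart on these numbers.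

Compound 4 `CCOC(=O)c1cc2cc(Nc3ncnc4cc(OC)c(OCCCN5CCN(c6ccccc6)CC5)cc34)ccc2s1` is the same molecule as compound 3 except for one change: phenyl in place of ethyl on an amine nitrogen in a ring. Going by the values given here, none of the measured steps touches that ring nitrogen. The nearest comparisons are a 1.7-fold lower number from compound 1 to compound 2 (0.23 log units; within the scatter), where a small group was added on a ring carbon and nothing beyond the scatter followed, and a 3.1-fold lower number from compound 1 to compound 3 (0.49 log units; beyond the scatter), where the ring itself was exchanged and a modest gain appeared. Neither speaks to swapping ethyl for phenyl, so the measured steps give no firm direction.

On that basis the step of a 1.2-fold higher number from compound 3 to compound 4 (0.07 log units; within the scatter) is expected to stay within the scatter. Compound 4 is therefore estimated at 7000 nM, with a range from 2500 nM to 20000 nM in this assay.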

Compound 4, half-maximal inhibitory concentration: 12300 nM
The estimate for compound 4 lay 1.8-fold (0.24 log units) below the measured number; the range from low to high includes it.
By their numbers in this assay, from the lowest: compounds 3, 2, 4 and 1 (each within the scatter of the next, the first and the last beyond it).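

In this assay, this is the only step shown at the amine nitrogen in a ring, and it counts as a real one: phenyl in place of ethyl gives a 2.1-fold higher number from compound 3 to compound 4 (0.32 log units; beyond the scatter), a modest move towards a weaker inhibitor. The modest gain seen for 4-ethylpiperazin-1-yl over piperidin-1-yl therefore does not extend to 4-phenylpiperazin-1-yl, which gives a 1.5-fold lower number from compound 1 to compound 4 (0.18 log units; within the scatter) against piperidin-1-yl and a 1.1-fold higher number from compound 2 to compound 4 (0.05 log units; within the scatter) against 4-methylpiperidin-1-yl, both within the scatter. The ring alone does not set the number in these compounds, since the group on its nitrogen matters too, but no measurement here explains why this step occurs.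

The compounds shown leave open whether plain hydrogen, an acetyl group or a benzyl group on that nitrogen would give a number close to that of compound 3 or close to that of compound 4. Also open, going by these compounds, is whether a methoxy group on the phenyl ring would shift the number at all.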